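Nitro for ethoxy on the aryl ring: cytotoxicity notes

The source may report more compounds than this note shows. Statements on the series, on what has been measured and on what is new or still open speak of the compounds shown alone.

Compound 1 `CCOc1ccccc1-c1nnc(SCCn2c([N+](=O)[O-])cnc2C)o1`, compound 2 `CCOc1ccc(-c2nnc(SCCn3c([N+](=O)[O-])cnc3C)o2)cc1` and compound 3 `Cc1ncc([N+](=O)[O-])n1CCSc1nnc(-c2ccccc2[N+](=O)[O-])o1` form a small set; the difference between the cores of compound 1 and compound 2 is not broken down here. In a functional assay on MCF7 cells (Homo sapiens) for cytotoxicity, read by MTT assay, with a stated time of 48 h (a lower number here means a stronger inhibitor, a higher number a weaker inhibitor), compound 1 gives 25900 nM, compound 2 gives 16600 nM and compound 3 gives 18300 nM, and all three lie within the scatter of one another. The change nitro in place of ethoxy on an aromatic carbon gave a 1.4-fold lower number from compound 1 to compound 3 (0.15 log units; within the scatter). Compound 4 `Cc1ncc([N+](=O)[O-])n1CCSc1nnc(-c2ccc([N+](=O)[O-])cc2)o1` is not yet measured; it arises from compound 2 by nitro in place of ethoxy on an aromatic carbon, the same kind of change, though the place differs: ortho to a large group in compound 3, para to a large group in compound 4. Because a 1.4-fold lower number from compound 1 to compound 3 (0.15 log units; within the scatter) lies within the scatter, the step of a 1.3-fold lower number from compound 2 to compound 4 (0.11 log units; within the scatter) is expected to be similarly small. Compound 4 is therefore estimated at 13000 nM in this assay, between 6000 nM and 30000 nM.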

Compound 4, half-maximal inhibitory concentration: 12700 nM
Beside the measured number, compound 4's estimate is 1.0-fold (0.01 log units) above it; the range from low to high includes it.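

In this assay, nitro in place of ethoxy on the aromatic carbon para to a large group gave a 1.3-fold lower number from compound 2 to compound 4 (0.12 log units; within the scatter). Set beside the earlier step, the change carries across the two cores with a similar size: the same change on two cores in this assay, a 1.4-fold lower number (0.15 log units; within the scatter) from compound 1 to compound 3 and a 1.3-fold lower number (0.12 log units; within the scatter) from compound 2 to compound 4, 1.1-fold (0.03 log units) apart, within the scatter of two such steps. Going by these compounds alone, each step lies within the scatter, so this shows only that the swap leaves the number unresolved on both cores, not that nitro is better than ethoxy, and two pairs do not establish a rule for the series.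

The compounds shown leave open whether an amine or a carboxylic acid on the same aromatic carbon would give a step beyond the scatter. On these data alone, how a longer chain in place of ethoxy would read also stays open.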